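Nitro on the 4-chlorophenyl of compound 1

A few compounds are considered here, and "the series" means these few. Any claim that something is new, unique, unknown or untested is made for them only; others in the source may bear on it.

- compound 1 `O=C(/C(=C\c1ccc(Cl)cc1)S(=O)(=O)c1ccc(Br)cc1)c1ccc(Br)cc1` gives 50000 nM
- compound 2 `O=C(/C(=C\c1ccc(O)c([N+](=O)[O-])c1)SCc1ccccc1Cl)c1ccc(Cl)cc1` gives 10000 nM

Both values come from a functional assay on DU-145 cells (Homo sapiens) for inhibition, read by trypan blue exclusion, with a stated time of 96 h (a lower number here means a stronger inhibitor of growth, a higher number a weaker inhibitor of growth), and give only a first view of the series. Compound 1 has the higher of the two numbers, which makes it the weaker growth inhibitor, and its gap to compound 2 lies beyond the scatter. The two compounds differ in more than one place, so that gap cannot be assigned to any single group.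

Next is compound 3 `O=C(/C(=C\c1ccc(Cl)c([N+](=O)[O-])c1)S(=O)(=O)c1ccc(Br)cc1)c1ccc(Br)cc1`, which keeps the core of compound 1 and turns 4-chlorophenyl into 4-chloro-3-nitrophenyl. This places nitro in place of hydrogen on an aromatic carbon, ortho to a chloro group and meta to a large group (nitro in place of hydrogen on an aromatic carbon). For the measured compounds named here, no measured pair isolates this change. Going by the values given here, the only hint is that compound 2, at 10000 nM, also carries a nitro group, though its other differences make this weak support. A modest move toward stronger inhibition is therefore expected, and a step within the scatter would not surprise. The expected step is a 2.5-fold lower number from compound 1 to compound 3 (0.40 log units; beyond the scatter) in this assay. For compound 3 the estimated value is 20000 nM, with an expected range from 6000 nM to 60000 nM.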

Compound 3, concentration for 50% growth inhibition: 10000 nM
The estimate for compound 3 lay 2.0-fold (0.30 log units) above the measured number, and the stated range covers the measured number.
By their numbers in this assay, from the lowest: compounds 2 and 3 (each within the scatter of the next); then compound 1.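

In this assay, for the compounds shown here, the change from 4-chlorophenyl to 4-chloro-3-nitrophenyl gives a 5.0-fold lower number from compound 1 to compound 3 (0.70 log units; beyond the scatter), the only step so far that isolates a single group. On the core of compound 1, nitro in place of hydrogen on this aromatic carbon, ortho to a chloro group, therefore goes with stronger growth inhibition, although compound 3 still gives 10000 nM. Nothing measured here speaks to what lies behind this step.

Open, as far as these compounds go, is whether the step belongs to nitro itself or would also follow other groups on the same carbon; an amine, a carboxylic acid or a methoxy group there would separate these readings. Also open, from the compounds shown here alone, is whether nitro gives a step of this size on any core other than that of compound 1; compound 2 differs from compound 1 and compound 3 in more than one place, and steps to it cannot be read.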